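Linker swap on the shared core: carboxymethoxy for 2-carboxyethyl

The source may report more compounds than this note shows. Statements on the series, on what has been measured and on what is new or still open speak of the compounds shown alone.

Measured compounds in a functional assay on cells for antagonist activity at prostaglandin D2 receptor 2 (Homo sapiens), read by chemiluminescence and beta-arrestin recruitment, with stated times of 30 min and 60 min; on this read-out lower numbers stand for stronger inhibition and higher numbers for weaker inhibition:
compound 1 `O=C(O)CCC(=O)N(C1CC1)[C@H]1c2ccccc2N(C(=O)c2ccc(OC(F)(F)F)cc2)[C@H]2CC[C@H]21`, 24 nM
compound 2 `O=C(O)COC(=O)N(C1CC1)[C@H]1c2ccccc2N(C(=O)c2cccc(F)c2)[C@H]2CC[C@H]21`, 1.1 nM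
compound 3 `O=C(O)CCC(=O)N(C1CC1)[C@H]1c2ccccc2N(C(=O)c2ccc(F)cc2)[C@H]2CC[C@H]21`, 12 nM

Compound 3 stands second highest of the three numbers, with compound 1 nearest (a 2.0-fold lower number from compound 1 to compound 3 (0.30 log units; within the scatter)) and compound 2 furthest, a gap beyond the scatter.

Compound 4 `O=C(O)COC(=O)N(C1CC1)[C@H]1c2ccccc2N(C(=O)c2ccc(F)cc2)[C@H]2CC[C@H]21` differs from compound 3 by carboxymethoxy in place of 2-carboxyethyl on a carbonyl carbon. Among the compounds with values here, no measured step isolates this change: compound 2 differs from compound 3 in two places, so its value only hints that the carboxymethoxy variant may sit lower in this assay. The size of that hint is uncertain.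

Compound 4 is therefore expected at 3 nM, within 1 nM to 10 nM, an expected 4.0-fold lower number from compound 3 to compound 4 (0.60 log units; beyond the scatter).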

Compound 4, half-maximal inhibitory concentration: 1.4 nM
Estimate against measurement, compound 4: 2.1-fold (0.33 log units) above; measured number inside the range.
By their numbers in this assay, from the lowest: compounds 2 and 4 (each within the scatter of the next); then compounds 3 and 1 (each within the scatter of the next).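

In this assay, within the data shown here, carboxymethoxy in place of 2-carboxyethyl on a carbonyl carbon now stands alone as a single change and gives an 8.6-fold lower number from compound 3 to compound 4 (0.93 log units; beyond the scatter), which the earlier compounds could only hint at. With carboxymethoxy held, 4-fluorophenyl in place of 3-fluorophenyl gives a 1.3-fold higher number from compound 2 to compound 4 (0.10 log units; within the scatter), so these two aryl groups cannot be told apart here. Nothing on hand offers an explanation for the linker step.

Going by these compounds, whether the linker step carries over to the trifluoromethoxy group of compound 1 remains open. So does the effect of a longer chain, or of an amide in place of the carboxylic acid.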